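A few compounds are considered here, and "the series" means these few. Any claim that something is new, unique, unknown or untested is made for them only; others in the source may bear on it.

Measured so far in an ADME assay on HepG2 cells (Homo sapiens) for cytotoxicity, read by luminescence, CellTiter-Glo and ATP content, with a stated time of 72 h; on this read-out higher numbers stand for an effect only at larger amounts of compound and lower numbers for an effect already at smaller amounts:

- compound 1, `COc1cccc(CNCCCNc2ccnc3cc(C4CCCCC4)ccc23)c1O`, gives 1080 nM
- compound 2, `COc1ccc(F)cc1CNCCCNc1ccnc2cc(C3CCCCC3)ccc12`, gives 2290 nM
- compound 3, `COc1cccc(CNCCCNc2ccnc3cc(Cc4cccc(C(F)(F)F)c4)ccc23)c1O`, gives 1720 nM

Compound 2 holds the highest of the three numbers in this assay; against compound 3 the gap is within the scatter, while against compound 1 the step of a 2.1-fold higher number from compound 1 to compound 2 (0.33 log units; beyond the scatter) is beyond it. Compound 4, `COc1ccc(F)cc1CNCCCNc1ccnc2cc(-c3ccc(C(C)(C)C)cc3)ccc12`, differs from compound 2 in one place: 4-(tert-butyl)phenyl in place of cyclohexyl on an aromatic carbon. Within the data shown here, the one measured step that bears on the same place is a 1.6-fold higher number from compound 1 to compound 3 (0.20 log units; within the scatter), where the cyclohexyl was also replaced on that aromatic carbon and the number moved only within the scatter. On that basis a comparably small step is expected for compound 4 in this assay, if anything toward a slightly higher number, estimated as a 1.3-fold higher number from compound 2 to compound 4 (0.12 log units; within the scatter). For compound 4 the value in this assay is therefore expected around 3000 nM, with a plausible range from 1200 nM to 7500 nM.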

Compound 4, half-maximal effective concentration: 620 nM
Compound 4: the middle estimate sits 4.8-fold (0.68 log units) above what was measured, and the stated range ends above it.
By their numbers in this assay, from the lowest: compounds 4, 1, 3 and 2 (each within the scatter of the next, the first and the last beyond it).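

Replacing cyclohexyl on this aromatic carbon with 4-(tert-butyl)phenyl moves the number in this assay beyond the scatter and toward an effect at smaller amounts of compound, with a 3.7-fold lower number from compound 2 to compound 4 (0.57 log units; beyond the scatter). The earlier change at this carbon, a 1.6-fold higher number from compound 1 to compound 3 (0.20 log units; within the scatter), stayed within the scatter, so this position is not indifferent to what replaces cyclohexyl, at least with the 5-fluoro-2-methoxyphenyl side chain of compound 2. No supporting data bear on why this step occurs.

The compounds shown leave open whether the step belongs to the aromatic ring itself or to its tert-butyl group, which a plain phenyl or a 4-methoxyphenyl on the same carbon would help separate. Also open, from the compounds shown here alone, is whether 4-(tert-butyl)phenyl gives a similar step with the 2-hydroxy-3-methoxyphenyl side chain of compound 1.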